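Ring substituent and hepatocyte half-life in one series

The compounds below may be only part of what the source reports. "The series", "measured", "known", "first", "only" and "open" are said of these compounds alone.

Measured so far in an ADME assay on cells (Hepatocyte, Homo sapiens) for metabolic stability; on this read-out higher numbers stand for a longer-lived compound and lower numbers for a shorter-lived compound:
compound 1, `CC(=O)NC1CCC(CN2CCN(c3cc(=O)c4cc(C(F)(F)F)cc([N+](=O)[O-])c4s3)CC2)CC1`, gives > 1.55 h, a limit of the assay and not a number.
compound 2, `O=C(OC1CCC(CN2CCN(c3cc(=O)c4cc(C(F)(F)F)cc([N+](=O)[O-])c4s3)CC2)CC1)c1ccncc1`, gives 0.075 h.
compound 3, `O=C(OC1CCC(CN2CCN(c3cc(=O)c4cc(C(F)(F)F)cc([N+](=O)[O-])c4s3)CC2)CC1)c1ccccc1`, gives 0.603 h.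

Compound 3 stands highest of the two numbers, compound 2 nearest to it: an 8.0-fold higher number from compound 2 to compound 3 (0.91 log units; beyond the scatter). Compound 4, `O=c1cc(N2CCN(CC3CCC(NS(=O)(=O)c4ccccc4)CC3)CC2)sc2c([N+](=O)[O-])cc(C(F)(F)F)cc12`, differs from compound 3 in one place: (phenylsulfonyl)amino in place of benzoyloxy on a saturated ring carbon. Among the compounds with values here, two measured steps bear on swapping the group on this saturated ring carbon, an at least 2.5-fold lower number from compound 1 to compound 3 (0.41 log units; beyond the scatter) and an at least 20-fold lower number from compound 1 to compound 2 (1.31 log units; beyond the scatter), and both are beyond the scatter, so the group there clearly moves the half-life. Neither step holds a sulfonamide, so the direction is uncertain; the expected step is a 2.0-fold higher number from compound 3 to compound 4 (0.30 log units; within the scatter), toward compound 1. Compound 4 is estimated at 1.2 h, in the range 0.45 h to 3.2 h.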

Compound 4, half-life: > 1.55 h
Compound 4: only a limit was reported; the forecaster's own chance of this, stated with the estimate: 30%; at least 1.2-fold (0.11 log units) between middle value and limit.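

With (phenylsulfonyl)amino on the saturated ring carbon, the half-life moves clear of both esters, with an at least 2.5-fold higher number from compound 3 to compound 4 (0.41 log units; beyond the scatter) and an at least 20-fold higher number from compound 2 to compound 4 (1.31 log units; beyond the scatter) in this series. Compounds 3 and 4 both carry a phenyl ring, so that ring alone does not go with the shorter half-life of compound 3. Compound 4 gives > 1.55 h as a limit of the assay and not a number.

Going by these compounds, whether a plain amine or a carboxylic acid on this carbon would hold the half-life stays open. Phenylsulfonyl and acetyl on the amine nitrogen cannot be ranked, as the step between compound 1 and compound 4 cannot be read because both stand at one limit: the limit of > 1.55 h in this assay, at which 2 of the 4 values shown sit.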